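This account rests on a few compounds, and the source may have more. Where it says the series, first, only, none or still open, it means among the compounds named here.

Of the compounds shown here, three sharing one core have been tested in an assay on isolated protein for displacement of a labelled ligand from metabotropic glutamate receptor 5 (Homo sapiens), with a stated time of 60 min, tested at 1 uM; on this read-out lower numbers stand for less inhibition and higher numbers for more inhibition at the one concentration tested (going by the name of the read-out). Compound 1 `Cc1ccc(S(=O)(=O)c2cnc3cc(F)ccc3c2N2CCC(C)CC2)cc1C` gives 90%. Compound 2 `COc1ccc2ncc(S(=O)(=O)c3ccc(Cl)cc3)c(N3CCC(C)CC3)c2c1` gives 91%. Compound 3 `CC1CCN(c2c(S(=O)(=O)c3ccc(F)cc3)cnc3ccc(F)cc23)CC1` gives 87%. Compound 2 carries the highest of the three numbers, yet the gaps to compound 1 and to compound 3 both lie within the scatter, so no order among them can be read; all three sit close together at high inhibition.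

Compound 4 `COc1ccc2ncc(S(=O)(=O)c3cccc(C#N)c3)c(N3CCC(C)CC3)c2c1` differs from compound 2 in one place: 3-cyanophenyl in place of 4-chlorophenyl on a sulfonyl sulfur. Going by the values given here, no pair of measured compounds differs at this position, so nothing shows how this assay responds to such a change there. The change is expected to bring a step of a number 6 percentage points lower from compound 2 to compound 4 (within the scatter), none beyond the scatter. Compound 4 is therefore expected to give 85%, with a range from 70% to 95%.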

Compound 4, a percentage reported as inhibition, at one concentration (the size of the read-out at that concentration, not a potency): 90%
For compound 4 the middle estimate is 5 percentage points below the measured one, and the stated range covers the measured number.
By their numbers in this assay, from the lowest: compounds 3, 1, 4 and 2 (each within the scatter of the next).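

Going by these compounds alone, on the sulfonyl sulfur, 3-cyanophenyl in place of 4-chlorophenyl gives a number 1 percentage points lower from compound 2 to compound 4 (within the scatter) in this assay and is the first change seen at this position. This position therefore accepts a nitrile-bearing ring in place of a chlorine-bearing one, with no readable difference at this one concentration. Nothing measured here offers an explanation for this result.

Every group shown on the sulfonyl sulfur is a six-membered aromatic ring of carbon only. From the compounds shown here alone, whether a saturated ring such as cyclohexyl, or a phenyl ring carrying an amine or a carboxylic acid, would fit equally well remains open.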